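This account rests on a few compounds, and the source may have more. Where it says the series, first, only, none or still open, it means among the compounds named here.

In a functional assay on HOP-62 cells (Homo sapiens) for inhibition, read by sulforhodamine B assay (on this read-out lower numbers stand for stronger inhibition of growth and higher numbers for weaker inhibition of growth), compound 1 `Cc1ccc2[nH]c(-c3ccc(-c4ccc(-c5ccc(N(C)C)cc5)cc4)cc3)nc2c1` gives 4230 nM on this read-out, compound 2 `Oc1ccc(-c2ccc(-c3ccc(-c4nc5ccccc5[nH]4)cc3)cc2)cc1` gives 47200 nM and compound 3 `Cc1ccc2[nH]c(-c3ccc(-c4ccc(-c5ccc(OC(F)(F)F)cc5)cc4)cc3)nc2c1` gives 24200 nM in the same test. Compound 3 therefore lies within the scatter of compound 2 and sits higher than compound 1, with the step of a 5.7-fold higher number from compound 1 to compound 3 (0.76 log units; beyond the scatter) modest in size but beyond the scatter. That step is trifluoromethoxy in place of dimethylamino on an aromatic carbon.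

Compound 4 `Cc1ccc2[nH]c(-c3ccc(-c4ccc(-c5ccc(O)cc5)cc4)cc3)nc2c1` follows from compound 3 by hydrogen in place of trifluoromethyl on an oxygen on an aromatic ring, or trifluoromethoxy to hydroxy (hydrogen in place of trifluoromethyl on an oxygen on an aromatic ring). Among the compounds with values here, the only measured step that touches this group is the one from compound 1, and it does not include hydroxy. Within the data shown here, the nearest evidence for hydroxy is compound 2, the one measured compound with 4-hydroxyphenyl. In this assay compound 2 stands at 47200 nM and so within the scatter of compound 3, although the two also differ elsewhere.

As far as these compounds go, a step beyond the scatter is therefore not expected, and the direction stays open. The expected step is a 1.2-fold higher number from compound 3 to compound 4 (0.06 log units; within the scatter) as estimated here. For compound 4 the estimated value is 28000 nM with an expected range of 9000 nM to 70000 nM in this test.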

Compound 4, concentration for 50% growth inhibition: 41200 nM
For compound 4 the middle estimate is 1.5-fold (0.17 log units) below the measured one; low and high end bracket the measured number.
By their numbers in this assay, from the lowest: compound 1; then compounds 3, 4 and 2 (each within the scatter of the next).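

In this assay, hydrogen in place of trifluoromethyl on the oxygen gives a 1.7-fold higher number from compound 3 to compound 4 (0.23 log units; within the scatter), so trifluoromethoxy and hydroxy are not separated at this position, and methyl in place of hydrogen on the aromatic carbon of the shared core is not separated either, at a 1.1-fold lower number from compound 2 to compound 4 (0.06 log units; within the scatter). Dimethylamino now stands apart from two groups rather than one: hydroxy in its place gives a 9.7-fold higher number from compound 1 to compound 4 (0.99 log units; beyond the scatter), in the same direction as the earlier 5.7-fold higher number from compound 1 to compound 3 (0.76 log units; beyond the scatter), and no compound shown goes against this. Nothing on hand accounts for the gap between dimethylamino and the two oxygen-linked groups.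

As far as these compounds go, whether the gap depends on the nitrogen or on dimethylamino as a whole stays open, and a primary amine, a morpholine or a methoxy at the same position would help to separate those readings. From the compounds shown here alone, the methyl on the core is tested only in the pair carrying hydroxy, so its effect with dimethylamino in place is unknown, as is that of a larger group such as an ethyl or a chlorine on that carbon.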